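This account rests on a few compounds, and the source may have more. Where it says the series, first, only, none or still open, it means among the compounds named here.

Measured so far in a functional assay on CHO-K1 cells for antagonist activity at adenosine receptor A1 (Homo sapiens), read by a beta-galactosidase reporter and cAMP accumulation, with stated times of 15 min and 6 h; on this read-out lower numbers stand for stronger inhibition and higher numbers for weaker inhibition:
- compound 1 `Cc1ccc(-c2nc(N)c3cc(CCc4ccccc4)sc3n2)o1`: 2780 nM
- compound 2 `Cc1ccc(-c2nc(N)c3cc(C(C)c4ccccc4)sc3n2)o1`: 439 nM
- compound 3 `CCc1ccc(-c2nc(N)c3cc(Cc4ccccc4)sc3n2)o1`: 223 nM

Compound 3 carries the lowest of the three numbers; its gap to compound 2 lies within the scatter, so no order can be read between the two, whereas compound 1 sits clearly higher. Going by the values given here, the one step between neighbours, a 6.3-fold lower number from compound 1 to compound 2 (0.80 log units; beyond the scatter), concerns the side chain on the fused ring and not the group that changes next.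

Compound 4 `Nc1nc(-c2ncco2)nc2sc(Cc3ccccc3)cc12` differs from compound 3 by 1,3-oxazol-2-yl in place of 5-ethylfuran-2-yl on an aromatic carbon. Among the compounds with values here, no measured pair bears on this exchange, so the expectation rests on general caution rather than on a counted step. A shift to weaker inhibition is expected, of roughly a 3.6-fold higher number from compound 3 to compound 4 (0.55 log units; beyond the scatter). Compound 4 is therefore estimated at 800 nM in this assay , within 250 nM to 2500 nM.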

Compound 4, inhibition constant: 310 nM
The estimate for compound 4 lay 2.6-fold (0.41 log units) above the measured number; the measured number falls inside the stated range.
By their numbers in this assay, from the lowest: compounds 3, 4 and 2 (each within the scatter of the next); then compound 1.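

In this assay, the position between two ring nitrogen atoms accepts 1,3-oxazol-2-yl in place of 5-ethylfuran-2-yl with a 1.4-fold higher number from compound 3 to compound 4 (0.14 log units; within the scatter). The number therefore holds across this exchange, although the entering ring has fewer heavy atoms, one more hetero atom and one more hydrogen-bond acceptor. No supporting measurement bears on this result.

This single pair cannot separate the contributions of the ring and the ethyl group. As far as these compounds go, whether a phenyl ring or a morpholine at this position would keep the number remains open.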